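Amide Variation on a Shared Core and Alpha-1 Binding

The compounds below may be only part of what the source reports. "The series", "measured", "known", "first", "only" and "open" are said of these compounds alone.

Three compounds built on one shared core differ only in the group attached to the amide carbonyl. Compound 1 `CCCCNC(=O)C1CCN(c2nc(N)c3cc(OC)c(OC)cc3n2)CC1` carries a butylamino group and gives 0.67 nM in an assay on isolated protein for displacement of a labelled ligand from Adrenergic receptor alpha-1 (Rattus norvegicus); on this read-out lower numbers stand for stronger inhibition and higher numbers for weaker inhibition. Compound 2 `CCN(CC)C(=O)C1CCN(c2nc(N)c3cc(OC)c(OC)cc3n2)CC1` carries a diethylamino group and gives 1.11 nM in this assay. Compound 3 `COc1cc2nc(N3CCC(C(=O)N4CCOCC4)CC3)nc(N)c2cc1OC` carries a morpholin-4-yl group and gives 1.14 nM in this assay; this is the highest of the three numbers, but every step to it sits within the scatter: a 1.7-fold higher number from compound 1 to compound 3 (0.23 log units; within the scatter) and a 1.0-fold higher number from compound 2 to compound 3 (0.01 log units; within the scatter). Likewise a 1.7-fold higher number from compound 1 to compound 2 (0.22 log units; within the scatter).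

Compound 4 `COc1cc2nc(N3CCC(C(=O)N(C)Cc4ccccc4)CC3)nc(N)c2cc1OC` is not yet measured. It differs from compound 3 in that (benzyl(methyl)amino in place of morpholin-4-yl on a carbonyl carbon). All three measured steps concern the same position on the carbonyl carbon, and none of them moved the number beyond the scatter. A change at this position is therefore expected to leave the number roughly where it is, so the estimated step is a 1.1-fold lower number from compound 3 to compound 4 (0.06 log units; within the scatter). Compound 4 is expected to give about 1 nM in this assay, within a range from 0.4 nM to 2.5 nM.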

Compound 4, inhibition constant: 0.2 nM
The estimate for compound 4 lay 5.0-fold (0.70 log units) above the measured number, and the stated range ends above it.
By their numbers in this assay, from the lowest: compound 4; then compounds 1, 2 and 3 (each within the scatter of the next).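

Among the compounds shown here, the position on the carbonyl carbon is less indifferent than the earlier compounds suggested: butylamino, diethylamino and morpholin-4-yl stayed within the scatter of one another in this assay, whereas benzyl(methyl)amino stands apart from all three. Replacing morpholin-4-yl with it gives a 5.7-fold lower number from compound 3 to compound 4 (0.76 log units; beyond the scatter) and replacing diethylamino gives a 5.6-fold lower number from compound 2 to compound 4 (0.74 log units; beyond the scatter) while replacing butylamino gives a 3.4-fold lower number from compound 1 to compound 4 (0.53 log units; beyond the scatter) and so each comparison points the same way. Benzyl(methyl)amino is also the only one of these groups with an aromatic ring, but nothing available here explains the lower number.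

The compounds shown leave open whether the aromatic ring, the methyl or the whole group accounts for this step. A benzylamino group without the methyl, or a cyclohexylmethyl group in place of the benzyl, would help separate these possibilities.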